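The compounds below may be only part of what the source reports. "The series", "measured", "known", "first", "only" and "open" are said of these compounds alone.

Measured so far in a functional assay for antagonist activity at Alpha-1A adrenergic receptor (Oryctolagus cuniculus); a lower number here means tighter binding, a higher number weaker binding:
- compound 1 `CNC(=O)c1cccnc1NCCCN1CCN(c2ccccc2OC)CC1`: 1 nM
- compound 2 `COc1ccccc1N1CCN(CCCOc2ccccc2C(=O)N(C)C)CC1`: 3.98 nM
- compound 3 `CN(C)C(=O)c1cccnc1NCCCN1CCN(c2ccccc2)CC1`: 6.31 nM

Compound 3 stands at the highest of the three numbers in this assay. Its nearest neighbour is compound 2, whose number is lower but within the usual scatter, so no order between the two is claimed. Its furthest neighbour is compound 1, whose lower number lies beyond the scatter; compound 1 and compound 3 differ in more than one place, and only their two values are noted here, without attributing the gap to either change.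

The next compound, compound 4 `CN(C)C(=O)c1cccnc1NCCCN1CCN(c2ccccc2OCC(F)(F)F)CC1`, differs from compound 3 in one place: 2,2,2-trifluoroethoxy in place of hydrogen on an aromatic carbon. Among the compounds with values here, no single-change step between measured compounds covers this kind of substitution, so the expectation rests on the whole set. Compound 1 and compound 2 both carry an alkoxy group on the same aromatic carbon that is unsubstituted in compound 3, and both give lower numbers than compound 3, though only the gap to compound 1 exceeds the scatter.

Compound 4 is therefore expected to move toward a lower number, by a modest step that may not exceed the scatter, a 1.8-fold lower number from compound 3 to compound 4 (0.26 log units; within the scatter). The estimate for compound 4 in this assay is 3.5 nM, with a range from 1.2 nM to 10 nM.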

Compound 4, dissociation constant: 0.1 nM
For compound 4 the middle estimate is 35-fold (1.54 log units) above the measured one; measured number below the stated range.
By their numbers in this assay, from the lowest: compound 4; then compound 1; then compounds 2 and 3 (each within the scatter of the next).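

In this assay, within the data shown here, this is the first single-change step, and it falls on the aromatic carbon ortho to a large group: 2,2,2-trifluoroethoxy in place of hydrogen gives a 63-fold lower number from compound 3 to compound 4 (1.80 log units; beyond the scatter). The earlier compounds shown here all differed in more than one place, so they could not isolate this carbon; this step shows directly that a substituent there can shift the number by a large margin, with everything else in the structure held constant. The data shown contain no measurement that bears on the cause of a step of this size.

One substituent at one carbon cannot separate the part played by the ether oxygen from that of the three fluorines, so plain ethoxy, or a trifluoromethyl group placed directly on the same aromatic carbon, would be the informative single-change partners for compound 3. On these data alone, it also remains open whether 2,2,2-trifluoroethoxy gives a step of similar size on the core of compound 1 or the core of compound 2, where the same carbon already carries an alkoxy group.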